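This account rests on a few compounds, and the source may have more. Where it says the series, first, only, none or still open, it means among the compounds named here.

Working notes on the series. Three compounds have numbers in an assay on mitochondria (strain BALB/c) for inhibition of glycerol-3-phosphate acyltransferase 1, mitochondrial (Mus musculus), read by scintillation counting, with a stated time of 10 min; on this read-out higher numbers stand for weaker inhibition and lower numbers for stronger inhibition: compound 1 `CCCCCCCCS(=O)(=O)Nc1cc(-c2ccccc2Cl)ccc1C(=O)O`, compound 2 `CCCCCCCCS(=O)(=O)Nc1ccc(-c2ccc(Cl)cc2)cc1C(=O)O` and compound 3 `CCCCCCCCS(=O)(=O)Nc1cc(C(=O)c2ccc(CCCC)cc2)ccc1C(=O)O`. In this assay compound 1 gives 26900 nM, compound 2 gives 9200 nM and compound 3 gives 15800 nM. Compound 2 carries the lowest of the three numbers. Its gap to compound 3 lies within the scatter of repeated runs, so these two cannot be placed in order; its gap to compound 1 lies beyond the scatter. Going by the values given here, no two of the measured compounds differ in a single place, so no single-change step is available as a guide within the set.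

Compound 4 `CCCCCCCCS(=O)(=O)Nc1ccc(/C=C/c2ccccc2)cc1C(=O)O` is not yet measured in this assay. Against compound 2 the change is 2-phenylethenyl in place of 4-chlorophenyl on an aromatic carbon, the place being an aromatic carbon of a six-membered aromatic ring of carbon only, meta to a carboxy group and para to a large group. The measured compounds give no direct read on this change, so the step of a 1.2-fold higher number from compound 2 to compound 4 (0.08 log units; within the scatter) is expected to stay within the scatter, with no clear direction. For compound 4 the estimated value in this assay is 11000 nM, with a range from 4000 nM to 35000 nM.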

Compound 4, half-maximal inhibitory concentration: 16300 nM
Compound 4: the middle estimate sits 1.5-fold (0.17 log units) below what was measured; low and high end bracket the measured number.
By their numbers in this assay, from the lowest: compounds 2, 3, 4 and 1 (each within the scatter of the next, the first and the last beyond it).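

In this assay, going by these compounds alone, the exchange of 4-chlorophenyl for 2-phenylethenyl on this aromatic carbon gives a 1.8-fold higher number from compound 2 to compound 4 (0.25 log units; within the scatter) and is the first single-change step in the set, so at this place, meta to a carboxy group and para to a large group, the two groups cannot be told apart. The exchange removes the chlorine and adds a double bond outside aromatic rings, while a six-membered aromatic ring of carbon only stays in both groups, and taken together these differences leave the number within the scatter. Nothing on hand accounts for this outcome, and the step alone cannot separate what the chlorine and the double bond each contribute.

The compounds shown leave open whether this place would respond differently to a group of another kind, such as an amine, a carboxylic acid or a longer chain, since both groups compared here are free of hydrogen-bond donors and acceptors and carry no net charge. From the compounds shown here alone, it also stays open whether the 2-phenylethenyl group would give a similar number on a different aromatic carbon of the shared core.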